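The compounds below may be only part of what the source reports. "The series", "measured", "known", "first", "only" and "open" are said of these compounds alone.

Measured so far in an assay for inhibition of serine/threonine-protein kinase PLK2 (Homo sapiens), read by FRET and Z'-LYTE, with a stated time of 1 h; on this read-out lower numbers stand for stronger inhibition and higher numbers for weaker inhibition:
compound 1 `CC[C@@H]1C(=O)N(C)c2cnc(Nc3ccc(S(=O)(=O)NCCO)cc3)nc2N1C1CCCC1` gives 7.86 nM
compound 2 `CCC1C(=O)N(C)c2cnc(Nc3ccc(S(=O)(=O)NCC(C)C)cc3)nc2N1c1ccn(C)n1` gives 311 nM
compound 3 `CCCCNC(=O)c1ccc2c(ccn2-c2ncc3c(n2)N(c2ccn(C)n2)C(CC)C(=O)N3C)c1` gives 159 nM

Among these, compound 2 carries the highest number, which on this read-out means the weakest inhibition shown. Compound 3 sits close by, within the usual scatter, so the two cannot be ranked against each other; compound 1 lies far lower, a gap well beyond the scatter. The next compound, compound 4 `CCC1C(=O)N(C)c2cnc(Nc3ccc(S(N)(=O)=O)cc3)nc2N1c1ccn(C)n1`, has not yet been measured. It differs from compound 2 in one place: hydrogen in place of isobutyl on a sulfonamide nitrogen. For the measured compounds named here, no measured pair isolates this change, since compound 1 differs from compound 2 at more than one position. With little to lean on, the expected step is a 1.1-fold higher number from compound 2 to compound 4 (0.05 log units; within the scatter), within the scatter. Compound 4 is therefore estimated at 350 nM, within a range from 120 nM to 1000 nM.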

Compound 4, half-maximal inhibitory concentration: 121 nM
Compound 4: the middle estimate sits 2.9-fold (0.46 log units) above what was measured, and the stated range covers the measured number.
By their numbers in this assay, from the lowest: compound 1; then compounds 4, 3 and 2 (each within the scatter of the next, the first and the last beyond it).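

In this assay, hydrogen in place of isobutyl on a sulfonamide nitrogen gives a 2.6-fold lower number from compound 2 to compound 4 (0.41 log units; beyond the scatter), a modest gain in inhibition. The four carbons of the isobutyl group are therefore not needed for inhibition on this core, and the plain sulfamoyl group does better than isobutylsulfamoyl. Nothing at hand explains this step.

This single pair cannot show how inhibition changes with the size or type of the group on this nitrogen. A methyl group or a chain ending in an amine could fall on either side of compound 4.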